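Lengthening a Short Chain Toward a Bulkier Branch

A few compounds are considered here, and "the series" means these few. Any claim that something is new, unique, unknown or untested is made for them only; others in the source may bear on it.

For the measured compounds named here, compound 2 `C=CCn1ncc2c(C)nc(CCC)n2c1=O` is the only compound here with a number in a functional assay for inhibition, with Homo sapiens as the target (on this read-out lower numbers stand for stronger inhibition and higher numbers for weaker inhibition), where compound 2 gives 40000 nM. Compound 1 `C=CCn1ncc2c(C)nc(CC)n2c1=O` gives only the limit > 48000 nM in this assay, as noted in the limit of > 48000 nM in this assay, at which 1 of the 2 values shown sits. Going by the values given here, the one measured step, an at least 1.2-fold lower number from compound 1 to compound 2 (0.07 log units; that floor lies within the scatter), stays within the scatter. The change considered now is tert-butyl in place of propyl on an aromatic carbon, giving compound 3 `C=CCn1ncc2c(C)nc(C(C)(C)C)n2c1=O`. Since the earlier growth of that chain moved nothing beyond the scatter, no clear shift is expected. Compound 3 is estimated at 40000 nM, between 15000 nM and 100000 nM. The expected step is no change at the digits printed from compound 2 to compound 3 (within the scatter).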

Compound 3, half-maximal inhibitory concentration: > 48000 nM
Compound 3: a limit, no number; the forecaster's own chance of this, stated with the estimate: 40%; at least 1.2-fold (0.07 log units) between middle value and limit.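

Putting tert-butyl in place of propyl on this aromatic carbon gives an at least 1.2-fold higher number from compound 2 to compound 3 (0.07 log units; that floor lies within the scatter), so branching here brings no gain in this assay. The result for compound 3 is a limit, not a number, and the step between compound 1 and compound 3 cannot be read. Compound 3 thus joins compound 1 at the same limit: the limit of > 48000 nM in this assay, at which 2 of the 3 values shown sit.

As far as these compounds go, whether a longer chain than propyl would lower the number remains open. So does the effect of an amine or a carboxylic acid on this aromatic carbon.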